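A few compounds are considered here, and "the series" means these few. Any claim that something is new, unique, unknown or untested is made for them only; others in the source may bear on it.

Compound 1 `O=C(Nc1nc2ccc(Cl)cc2s1)c1cn(-c2ccccc2)nc1-c1ccccc1` is the reference of the set; in a functional assay on A549 cells (Homo sapiens) for cytotoxicity, read by MTT assay, with a stated time of 72 h (a higher number here means a weaker inhibitor, a lower number a stronger inhibitor), compound 1 gives 7670 nM. Compound 2 `COc1ccc2nc(NC(=O)c3cn(-c4ccccc4)nc3-c3ccccc3)sc2c1` differs from it by methoxy in place of chloro on an aromatic carbon. In this assay compound 2 reports only a limit, > 50000 nM, which is the limit of > 50000 nM in this assay, at which 1 of the 3 values shown sits. The step is an at least 6.5-fold higher number from compound 1 to compound 2 (0.81 log units; beyond the scatter). Compound 3 `O=C(Nc1nc2ccc(Cl)cc2s1)c1cn(-c2ccccc2)nc1-c1ccc(Cl)cc1` differs from compound 1 by chloro in place of hydrogen on an aromatic carbon; in this assay compound 3 gives 4360 nM, a step of a 1.8-fold lower number from compound 1 to compound 3 (0.25 log units; within the scatter). Compound 4 `COc1ccc2nc(NC(=O)c3cn(-c4ccccc4)nc3-c3ccc(Cl)cc3)sc2c1` differs from compound 3 by methoxy in place of chloro on an aromatic carbon, the same change as between compound 1 and compound 2, at the same place. The step of an 8.0-fold higher number from compound 3 to compound 4 (0.90 log units; beyond the scatter) is expected, resting on the measured step of an at least 6.5-fold higher number from compound 1 to compound 2 (0.81 log units; beyond the scatter). Compound 4 is estimated at 35000 nM, from 15000 nM to 100000 nM. A limit rather than a number may well result for compound 4.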

Compound 4, half-maximal inhibitory concentration: 31400 nM
Estimate against measurement, compound 4: 1.1-fold (0.05 log units) above, and the stated range covers the measured number.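

Methoxy in place of chloro on the aromatic carbon carries over in direction in this assay, with a 7.2-fold higher number from compound 3 to compound 4 (0.86 log units; beyond the scatter), and both steps lie beyond the scatter: the same change on two cores in this assay, an at least 6.5-fold higher number (0.81 log units; beyond the scatter) from compound 1 to compound 2 and a 7.2-fold higher number (0.86 log units; beyond the scatter) from compound 3 to compound 4; the limit leaves it open whether they differ. Chloro in place of hydrogen gives an at least 1.5-fold lower number from compound 2 to compound 4 (0.20 log units; that floor lies within the scatter), and neither core shows a step beyond the scatter for this change: the same change on two cores in this assay, a 1.8-fold lower number (0.25 log units; within the scatter) from compound 1 to compound 3 and an at least 1.5-fold lower number (0.20 log units; that floor lies within the scatter) from compound 2 to compound 4; the limit leaves it open whether they differ. Compound 2 is reported only as a limit, so the comparison of step sizes remains unresolved, and the transfer rests on two cores only: the limit of > 50000 nM in this assay, at which 1 of the 4 values shown sits.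

The compounds shown leave open how an amine or a carboxylic acid would compare with chloro and methoxy at the same aromatic carbon. They also leave open whether either change carries over to a core with a different group on the phenyl rings.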